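Exchanges at one chain carbon on the shared core

A few compounds are considered here, and "the series" means these few. Any claim that something is new, unique, unknown or untested is made for them only; others in the source may bear on it.

Compound 1 `CCCn1c(=N)sc2cc(OC(F)(F)F)ccc21` (value 4.5 mg/kg)
Compound 2 `C#CCn1c(=N)sc2cc(OC(F)(F)F)ccc21` (value 4 mg/kg)
Compound 3 `N=c1sc2cc(OC(F)(F)F)ccc2n1CC(N)=O` (value 7 mg/kg)

All three values come from a functional assay on the whole organism with Rattus norvegicus as the target (on this read-out higher numbers stand for an effect only at larger amounts of compound and lower numbers for an effect already at smaller amounts), and cannot be told apart. The data show a 1.6-fold higher number from compound 1 to compound 3 (0.19 log units; within the scatter) and also a 1.8-fold higher number from compound 2 to compound 3 (0.24 log units; within the scatter) so compound 3 stands level with both neighbours within the scatter. The remaining pair shows the same picture with a 1.1-fold lower number from compound 1 to compound 2 (0.05 log units; within the scatter) as its step.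

Compound 4 `CNS(=O)(=O)CCn1c(=N)sc2cc(OC(F)(F)F)ccc21` carries (methylsulfamoyl)methyl in place of carbamoyl on a saturated chain carbon bound to an aromatic nitrogen. The counted difference reads (methylsulfamoyl)methyl in place of carbamoyl on a saturated chain carbon bound to an aromatic nitrogen and the same change can also be read as carbamoylmethyl to 2-(methylsulfamoyl)ethyl.

All three measured steps were made at this same place, and the two that bring in carbamoyl bear most directly on the exchange. Within the data shown here, none of the three left the scatter, but no measured compound carries a group like the entering one, so the evidence is indirect and the range is kept wide. No step beyond the scatter is expected in this assay and no direction is claimed. The expected step is a 1.2-fold lower number from compound 3 to compound 4 (0.07 log units; within the scatter) and it is only an estimate. Compound 4 is estimated at 6 mg/kg with an expected range from 2.5 mg/kg to 15 mg/kg in this assay until the measurement is in.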

Compound 4, dose for half-maximal effect: 4 mg/kg
Estimate against measurement, compound 4: 1.5-fold (0.18 log units) above, within the range that was stated.
By their numbers in this assay, from the lowest: compounds 2, 4, 1 and 3 (each within the scatter of the next).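

At the saturated chain carbon bound to an aromatic nitrogen, (methylsulfamoyl)methyl, which has more heavy atoms than the carbamoyl it replaces, leaves the read-out in this assay within the scatter (a 1.8-fold lower number from compound 3 to compound 4 (0.24 log units; within the scatter)). The same holds against the other two compounds (no change at the digits printed from compound 2 to compound 4 (within the scatter); a 1.1-fold lower number from compound 1 to compound 4 (0.05 log units; within the scatter)), so all four chains on the shared core cannot be told apart here, and the range of groups accepted at this place now includes one bearing a methylsulfamoyl end. Nothing measured alongside these doses speaks to the reason for this flat picture, and the whole-animal values alone cannot supply one.

Among these compounds, open is whether the picture persists with a primary amine, a carboxylic acid or a chain longer than 2-(methylsulfamoyl)ethyl at this place, since any of these could yet give the first step beyond the scatter in this assay. Also open, going by these compounds, is whether a ring-bearing group such as phenyl or morpholine on this chain carbon would fit the same flat picture, or whether the set merely samples a narrow part of what this place accepts.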